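Sulfonyl aryl variation on the shared core: naphthyl analogue

This account rests on a few compounds, and the source may have more. Where it says the series, first, only, none or still open, it means among the compounds named here.

Two members of the series have a number in a functional assay on PC-3 cells (Homo sapiens) for inhibition; on this read-out higher numbers stand for weaker inhibition and lower numbers for stronger inhibition. Compound 1 `COc1cc2nc(N3CCN(S(=O)(=O)c4cccc([N+](=O)[O-])c4)CC3)nc(N)c2cc1OC` gives 32000 nM. Going by the values given here, compound 2 `COc1cc2nc(N3CCN(S(=O)(=O)c4ccc(C(C)(C)C)cc4)CC3)nc(N)c2cc1OC` gives 4100 nM, the lowest of the two numbers so far; the step of a 7.8-fold lower number from compound 1 to compound 2 (0.89 log units; beyond the scatter) is the only measured step on the sulfonyl sulfur. Compound 3 `COc1cc2nc(N3CCN(S(=O)(=O)c4ccc5ccccc5c4)CC3)nc(N)c2cc1OC` is not yet measured. It differs from compound 2 in one place: naphthalen-2-yl in place of 4-(tert-butyl)phenyl on a sulfonyl sulfur. The measured step bears only indirectly on this change, since it removes a different group from the same sulfonyl sulfur; nothing measured tells how naphthalen-2-yl compares with 4-(tert-butyl)phenyl. No step beyond the scatter is therefore expected in this assay, though the range is kept wide. The expected step of a 1.2-fold lower number from compound 2 to compound 3 (0.07 log units; within the scatter) is small. Compound 3 is estimated at 3500 nM, with a range from 1000 nM to 12000 nM.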

Compound 3, half-maximal inhibitory concentration: 15000 nM
Estimate against measurement, compound 3: 4.3-fold (0.63 log units) below; measured number above the stated range.
By their numbers in this assay, from the lowest: compound 2; then compound 3; then compound 1.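

In this assay, the group on the sulfonyl sulfur matters even between two groups of equal heavy-atom count and carbon only: naphthalen-2-yl in place of 4-(tert-butyl)phenyl raises the number (a 3.7-fold higher number from compound 2 to compound 3 (0.56 log units; beyond the scatter)). Naphthalen-2-yl in place of 3-nitrophenyl still lowers it (a 2.1-fold lower number from compound 1 to compound 3 (0.33 log units; beyond the scatter)), so the three groups now form an order with every step beyond the scatter: 4-(tert-butyl)phenyl gives the lowest number, naphthalen-2-yl an intermediate one and 3-nitrophenyl the highest. A second aromatic ring in place of the tert-butyl-bearing ring therefore brings no gain over compound 2.

Nothing available explains the difference between these groups. On these data alone, it remains open whether a small alkyl group such as methyl, or an aryl group carrying an amine or a carboxylic acid, on the sulfonyl sulfur would give a number lower than that of compound 2.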